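The compounds below may be only part of what the source reports. "The series", "measured", "known", "first", "only" and "open" are said of these compounds alone.

Compound 1 `O=c1cc(-c2ccccc2)oc2cc(OCCCCNc3nc4ccccc4s3)cc(O)c12` gives 8.57 ug/mL in a physicochemical assay, read by spectrophotometry, with a stated time of 10 min; on this read-out higher numbers stand for weaker inhibition and lower numbers for stronger inhibition.
Compound 2 `O=c1cc(-c2ccccc2)oc2cc(OCCCCNc3nc4ccc(Cl)cc4s3)cc(O)c12` gives 4.16 ug/mL in this assay.
Compound 3 `O=c1cc(-c2ccccc2)oc2cc(OCCCCNc3nc4ccc(I)cc4s3)cc(O)c12` gives 9.84 ug/mL in this assay.

Compound 3 carries the highest of the three numbers. Its nearest neighbour is compound 1, since a 1.1-fold higher number from compound 1 to compound 3 (0.06 log units; within the scatter); its furthest is compound 2, since a 2.4-fold higher number from compound 2 to compound 3 (0.37 log units; beyond the scatter).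

The unmeasured compound 4 `O=c1cc(-c2ccccc2)oc2cc(OCCCCNc3nc4c(F)cc(F)cc4s3)cc(O)c12` differs from compound 3 in one place: 4,6-difluoro-1,3-benzothiazol-2-yl in place of 6-iodo-1,3-benzothiazol-2-yl on an amine nitrogen. Within the data shown here, no measured step exchanges a halogen for fluorine, and none puts two halogens on the ring, so the bearing of the known steps is indirect. The steps that touch the same ring are a 2.1-fold lower number from compound 1 to compound 2 (0.31 log units; beyond the scatter), a 1.1-fold higher number from compound 1 to compound 3 (0.06 log units; within the scatter) and a 2.4-fold higher number from compound 2 to compound 3 (0.37 log units; beyond the scatter). Two of these three lie beyond the scatter only modestly, and the third lies within it, so the halogen on this ring has so far shifted the number by at most a modest amount in either direction.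

On that basis compound 4 is expected to show a small downward step, a 1.5-fold lower number from compound 3 to compound 4 (0.18 log units; within the scatter), that may not clear the scatter. The estimate for compound 4 is 6.5 ug/mL, with a range from 3 ug/mL to 13 ug/mL.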

Compound 4, half-maximal inhibitory concentration: 5.76 ug/mL
Compound 4: the middle estimate sits 1.1-fold (0.05 log units) above what was measured; the measured number falls inside the stated range.
By their numbers in this assay, from the lowest: compounds 2, 4, 1 and 3 (each within the scatter of the next, the first and the last beyond it).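

In this assay the step to the 4,6-difluoro-1,3-benzothiazol-2-yl group, a 1.7-fold lower number from compound 3 to compound 4 (0.23 log units; within the scatter), is no larger than the scatter, and the same holds for a 1.4-fold higher number from compound 2 to compound 4 (0.14 log units; within the scatter) and for a 1.5-fold lower number from compound 1 to compound 4 (0.17 log units; within the scatter). Among these compounds, this is the first compound with two halogens on the ring, and it adds no step beyond the scatter, although compound 2 and compound 3 stand apart by a 2.4-fold higher number from compound 2 to compound 3 (0.37 log units; beyond the scatter) and compound 4 cannot be told from either of them. So, among these four compounds, the exchange of iodo for two fluorines leaves the number inside the modest span already set by the chloro and iodo compounds, and nothing available here accounts for that result.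

On these data alone, what a single fluorine, a methoxy group or a nitrile would do on this ring remains open, as does the effect of a longer chain on the amine nitrogen. The compounds shown also leave open whether any group on this ring can move the number further than the modest gap between compound 2 and compound 3.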